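A few compounds are considered here, and "the series" means these few. Any claim that something is new, unique, unknown or untested is made for them only; others in the source may bear on it.

Among the compounds with values here, in a functional assay on U-87MG ATCC cells for antiproliferative activity against U-87 MG (Homo sapiens), read by MTT assay, with a stated time of 48 h (a higher number here means a weaker inhibitor, a lower number a stronger inhibitor), compound 2 (`Cc1nc(-c2ccccc2)sc1C(=O)CSc1nc(-c2ccccc2)c(C#N)c(=O)[nH]1`) gives 56600 nM and so holds the higher of the two numbers measured so far, which makes it the weaker of the pair. Compound 1 (`COc1ccc(-c2nc(C)c(C(=O)CSc3nc(-c4ccc(OC)cc4)c(C#N)c(=O)[nH]3)s2)cc1`) gives 25300 nM in this assay and the gap between the two lies beyond the scatter. Compound 3 (`COc1ccc(-c2nc(C)c(C(=O)CSc3nc(-c4ccccc4)c(C#N)c(=O)[nH]3)s2)cc1`) departs from compound 2 at a single place: methoxy in place of hydrogen on an aromatic carbon (methoxy in place of hydrogen on an aromatic carbon, which turns a phenyl into a 4-methoxyphenyl). Within the data shown here, no measured pair shows this change alone. Compound 1 (25300 nM) carries this methoxy as well, but it differs from compound 2 at a second place too, so its lower number suggests only a direction. A modest shift towards a lower number is therefore expected, with a 1.5-fold lower number from compound 2 to compound 3 (0.17 log units; within the scatter) estimated to stay within the scatter or close to its edge. For compound 3 the estimated value is 38000 nM with an expected range from 18000 nM to 75000 nM in this assay once it is measured.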

Compound 3, half-maximal inhibitory concentration: 57300 nM
The estimate for compound 3 lay 1.5-fold (0.18 log units) below the measured number; measured number inside the range.
By their numbers in this assay, from the lowest: compound 1; then compounds 2 and 3 (each within the scatter of the next).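

In this assay, the phenyl to 4-methoxyphenyl change at this position, with methoxy para to a large group, can now be read alone, and it gives a 1.0-fold higher number from compound 2 to compound 3 (0.01 log units; within the scatter), so methoxy on this ring shows no effect beyond the scatter. Within the data shown here, the methoxy on the other phenyl of the shared core behaves differently, as replacing it with hydrogen gives a 2.3-fold higher number from compound 1 to compound 3 (0.36 log units; beyond the scatter), and the direction hinted at by the earlier compounds therefore belongs to that other ring and not to this one. No measurement of any other kind is available to explain why the two rings differ.

Only hydrogen and methoxy are shown on either ring, so it remains open whether a hydroxyl, a chlorine or an amine at this position would also stay within the scatter of hydrogen, or whether this carbon tolerates substitution generally. It also remains open whether a group such as an ethoxy or a dimethylamino on the other phenyl would extend the step seen there, since every number shown here sits in a similar weak range.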